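Trimming the benzyloxy group of compound 1 to methoxy

A few compounds are considered here, and "the series" means these few. Any claim that something is new, unique, unknown or untested is made for them only; others in the source may bear on it.

Measured in a functional assay on thoracic aorta (Rattus norvegicus, strain Wistar), with a stated time of 15 min; a higher number here means that more compound is needed for the effect, a lower number that less compound is needed:
- compound 1 `CC(NC(=O)NS(=O)(=O)c1ccc(Cl)cc1)c1cc(Br)ccc1OCc1ccccc1`: 57500 nM
- compound 2 `CC(NC(=O)NS(=O)(=O)c1ccc(Cl)cc1)c1ccccc1OCc1ccccc1`: 157000 nM
- compound 3 `CC(NC(=O)NS(=O)(=O)c1ccccc1)c1cc(Br)ccc1OCc1ccccc1`: 130000 nM

Compound 1 has the lowest number of the three. The smallest gap from it is a 2.3-fold higher number from compound 1 to compound 3 (0.35 log units; beyond the scatter), and the largest is a 2.7-fold higher number from compound 1 to compound 2 (0.44 log units; beyond the scatter).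

Compound 4 `COc1ccc(Br)cc1C(C)NC(=O)NS(=O)(=O)c1ccc(Cl)cc1` has not yet been measured. It differs from compound 1 as follows: hydrogen in place of phenyl on a saturated chain carbon bound to an oxygen on an aromatic ring. In short, benzyloxy becomes methoxy. For the measured compounds named here, no measured step touches this group, so the evidence is only indirect. The two available steps each replace a halogen with hydrogen rather than phenyl. Both were modest and both raised the number, as a 2.7-fold higher number from compound 1 to compound 2 (0.44 log units; beyond the scatter) and a 2.3-fold higher number from compound 1 to compound 3 (0.35 log units; beyond the scatter) show. From the compounds shown here alone, a modest rise in this assay is therefore expected, though a step of this kind remains untested. The estimated change is a 2.3-fold higher number from compound 1 to compound 4 (0.35 log units; beyond the scatter). Compound 4 is expected at about 130000 nM, within an estimated range of 40000 nM to 400000 nM.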

Compound 4, half-maximal effective concentration: 80900 nM
Estimate against measurement, compound 4: 1.6-fold (0.21 log units) above; the measured number falls inside the stated range.
By their numbers in this assay, from the lowest: compounds 1, 4, 3 and 2 (each within the scatter of the next, the first and the last beyond it).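

For the compounds shown here, this is the first step to touch the benzyloxy group, and in this assay the replacement of phenyl by hydrogen gives a 1.4-fold higher number from compound 1 to compound 4 (0.15 log units; within the scatter). Compound 1 thus loses its six-carbon aromatic ring with no change beyond the scatter, whereas the two halogen steps, a 2.7-fold higher number from compound 1 to compound 2 (0.44 log units; beyond the scatter) and a 2.3-fold higher number from compound 1 to compound 3 (0.35 log units; beyond the scatter), each went beyond it. Nothing available on the compounds explains this result.

Benzyloxy and methoxy are the only groups shown at this place, so it stays open how a hydroxy group, an ethoxy group or a longer chain ending in an amine or a carboxylic acid would read in this assay. From the compounds shown here alone, it also stays open whether removing the bromo or the chloro group from compound 4 would give steps like those seen from compound 1.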